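Amine tail exchanged for an ester: an expected step

The compounds below may be only part of what the source reports. "The series", "measured", "known", "first", "only" and "open" are said of these compounds alone.

Measured so far:
- compound 2 `COc1cc(OC)c(C(=O)/C=C/c2ccccc2Cl)c(O)c1CN(C)CCCN(C)C`: 30900 nM
- compound 1 `COc1cc(O)c2c(=O)cc(-c3ccccc3Cl)oc2c1CN1CCCCC1`: 118000 nM

Compound 2 holds the lower of the two numbers in a functional assay on Bel-7402 cells (Homo sapiens) for antiproliferative activity, with a stated time of 72 h; on this read-out higher numbers stand for weaker inhibition and lower numbers for stronger inhibition; compound 1, built on a different core, gives 118000 nM, and the gap between the two lies beyond the scatter. Compound 3 `COC(=O)CN(C)Cc1c(OC)cc(OC)c(C(=O)/C=C/c2ccccc2Cl)c1O` has not yet been measured in this assay. It differs from compound 2 in one place: methoxycarbonyl in place of 2-(dimethylamino)ethyl on a saturated chain carbon bound to an amine nitrogen. For the measured compounds named here, no measured pair of compounds traces a step of this kind, so nothing in the numbers fixes its size. The expectation is that the step from compound 2 to compound 3 in this assay is upward and modest, with a 1.9-fold higher number from compound 2 to compound 3 (0.29 log units; within the scatter) as the estimated move, since compound 2 sets the only direct reference point at 30900 nM. Compound 3 is accordingly expected to give about 60000 nM, within a range of 20000 nM to 200000 nM.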

Compound 3, half-maximal inhibitory concentration: 8500 nM
Compound 3: the middle estimate sits 7.1-fold (0.85 log units) above what was measured; the whole stated range lies above it.
By their numbers in this assay, from the lowest: compound 3; then compound 2; then compound 1.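

In this assay, methoxycarbonyl in place of 2-(dimethylamino)ethyl on a saturated chain carbon bound to an amine nitrogen gives a 3.6-fold lower number from compound 2 to compound 3 (0.56 log units; beyond the scatter), so the tail at this position bears on the read-out by more than the scatter. The nitrogen at the end of the tail in compound 2 is absent from compound 3, and so it is not required for the inhibition seen here. Nothing measured alongside these compounds accounts for the size or direction of this step.

The compounds shown leave open whether the ester itself matters, or whether a carboxylic acid, a primary amide or a longer chain ending in methoxycarbonyl would read the same at this place. Compound 1 differs from both others in its core, so what the core contributes cannot be read.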